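A few compounds are considered here, and "the series" means these few. Any claim that something is new, unique, unknown or untested is made for them only; others in the source may bear on it.

Compound 1, with the structure `COc1cc(-c2cc(/C=C/C(=O)c3ccc(N)cc3)[nH]n2)cc(OC)c1OC`, was tested in a functional assay on OVCAR-3 cells (Homo sapiens) for cytotoxicity, read by sulforhodamine B assay, with a stated time of 48 h, tested at 0.01 uM (a higher number here means a weaker effect of the compound at the concentration tested, a lower number a stronger effect), where compound 1 gives 101%. Its number sits in the middle of three: compound 2, `COc1ccc(-c2cc(/C=C/C(=O)c3cc(OC)c(OC)c(OC)c3)[nH]n2)cc1OC`, gives 99% in this assay, and compound 3, `COc1ccc(-c2cc(/C=C/C(=O)c3ccc(N)cc3)[nH]n2)cc1`, gives 104%, and both differences from compound 1 lie within the usual scatter, so the three compounds cannot be told apart at this concentration. Compound 4, `COc1cc(-c2cc(/C=C/C(=O)c3ccc(F)c(F)c3)[nH]n2)cc(OC)c1OC`, differs from compound 1 in one place: 3,4-difluorophenyl in place of 4-aminophenyl on a carbonyl carbon. Among the compounds with values here, no measured pair shows the effect of such a change here. Since all three measured compounds sit at essentially full activity, compound 4 is expected to do the same, with a step of a number 1 percentage points lower from compound 1 to compound 4 (within the scatter) that stays within the scatter. Compound 4 is therefore estimated at 100%, within a range of 88% to 110%.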

Compound 4, a percentage reported as activity, at one concentration (the size of the read-out at that concentration, not a potency): 102%
For compound 4 the middle estimate is 2 percentage points below the measured one, and the stated range covers the measured number.
By their numbers in this assay, from the lowest: compounds 2, 1, 4 and 3 (each within the scatter of the next).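

In this assay, within the data shown here, placing 3,4-difluorophenyl instead of 4-aminophenyl on the carbonyl carbon gives a number 1 percentage points higher from compound 1 to compound 4 (within the scatter), the first step that can be read at this position. Removing the amino group and adding two fluorines therefore leaves the read-out unchanged at this concentration, although neither compound shows a clear effect there, so this says little about how much the position matters. No available evidence bears on this result. On these data alone, whether a carboxylic acid or a morpholine on the carbonyl carbon would shift the number remains open.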